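Cytotoxicity limits and a methoxy addition

The compounds below may be only part of what the source reports. "The series", "measured", "known", "first", "only" and "open" are said of these compounds alone.

Measured in an ADME assay on A549 cells (Homo sapiens) for cytotoxicity, read by MTT assay; a lower number here means that less compound is tolerated, a higher number that more compound is tolerated:
- Compound 1 `CCN(c1ccccc1C)S(=O)(=O)c1cc(Cl)ccc1Cl`: > 25000 nM, a limit
- Compound 2 `CCN(c1ccc(Cl)cc1C)S(=O)(=O)c1cc(Cl)ccc1Cl`: > 5000 nM, a limit

Going by the values given here, the only reading for compound 2 is a limit, > 5000 nM. Compound 3 `COCCN(c1ccc(Cl)cc1C)S(=O)(=O)c1cc(Cl)ccc1Cl` differs from it by one change, (methoxy in place of hydrogen on a saturated chain carbon, two bonds along the chain from a sulfonamide nitrogen), which turns ethyl to 2-methoxyethyl. Among the compounds with values here, the sole measured step, a step that the two limits leave unreadable from compound 1 to compound 2, has no readable size and lies at another place, so it offers no guide. No step beyond the scatter is therefore expected in this assay, and no direction can be given. The expected step is a step that the limit leaves unreadable from compound 2 to compound 3. For compound 3 the estimated value is 9000 nM, with an expected range of 3000 nM to 30000 nM.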

Compound 3, half-maximal cytotoxic concentration: > 5000 nM
Compound 3: a limit, no number; the forecaster's own chance of this, stated with the estimate: 70%; the middle value does not contradict the limit.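

Going by these compounds alone, compound 2 and compound 3 both stand only as limits in this assay, and no step between them can be read. The compounds shown leave open the concentration at which any of them becomes cytotoxic.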